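Swapping 3-methoxyphenyl for 4-nitrophenyl

This account rests on a few compounds, and the source may have more. Where it says the series, first, only, none or still open, it means among the compounds named here.

In a functional assay on HepG2 cells (Homo sapiens) for antiproliferative activity, read by MTT assay, with a stated time of 48 h (on this read-out higher numbers stand for weaker inhibition and lower numbers for stronger inhibition), compound 1 `Fc1ccc(N2CCN(Cn3nc(-c4ccc5c(c4)OCCO5)oc3=S)CC2)cc1` gives > 50000 nM, which is a limit of the assay and not a number. For the measured compounds named here, compound 2 `COc1cccc(N2CCN(Cn3nc(-c4ccc5c(c4)OCCO5)oc3=S)CC2)c1` gives 21400 nM, the only true number so far. Compound 3 `O=[N+]([O-])c1ccc(N2CCN(Cn3nc(-c4ccc5c(c4)OCCO5)oc3=S)CC2)cc1` has not yet been measured. It carries 4-nitrophenyl in place of 3-methoxyphenyl on an amine nitrogen in a ring. Going by the values given here, the one measured step that bears on this change is an at least 2.3-fold lower number from compound 1 to compound 2 (0.36 log units; beyond the scatter), and it replaced 4-fluorophenyl with 3-methoxyphenyl at that same nitrogen. The 4-nitrophenyl group resembles the 4-fluorophenyl group of compound 1 in carrying its substituent at the 4 position, so part of that gain may be lost again. A small move toward higher numbers in this assay is therefore expected, a 1.6-fold higher number from compound 2 to compound 3 (0.21 log units; within the scatter). For compound 3 the estimated value is 35000 nM, with an expected range of 14000 nM to 70000 nM.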

Compound 3, half-maximal inhibitory concentration: 29500 nM
Beside the measured number, compound 3's estimate is 1.2-fold (0.07 log units) above it, and the stated range covers the measured number.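

The change from 3-methoxyphenyl to 4-nitrophenyl on this ring nitrogen gives a 1.4-fold higher number from compound 2 to compound 3 (0.14 log units; within the scatter), so in this assay these two groups cannot be told apart. Nitro in place of fluoro gives an at least 1.6-fold lower number from compound 1 to compound 3 (0.22 log units; that floor lies within the scatter), so this pair is not firmly separated either, though compound 3 gives a true number where the other 4-substituted phenyl compound does not. Compound 1 stands at a limit of the assay and not at a number, so its step to compound 3 has only a floor: the limit of > 50000 nM in this assay, at which 1 of the 3 values shown sits.

The compounds shown leave open what an unsubstituted phenyl or a 4-methoxyphenyl would give on this nitrogen, which would set the place of a substituent apart from its kind. They also leave open whether a pyridine ring here would move the number beyond the scatter.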